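Predicting the Cytotoxicity of Compound 4

The source may hold more compounds than are shown below. What is called first, only, known or untested is meant among the compounds shown, and "the series" means these compounds.

Compound 1 `CCOC(=O)NC(=O)NC1=CS(=O)(=O)O[C@@]12[C@@H](CO[Si](C)(C)C(C)(C)C)O[C@@H](n1cc(C)c(=O)n(C)c1=O)[C@@H]2O[Si](C)(C)C(C)(C)C`: 14000 nM
Compound 2 `Cc1cn([C@@H]2O[C@H](CO[Si](C)(C)C(C)(C)C)[C@@]3(OS(=O)(=O)C=C3NC(=O)c3ccccc3)[C@H]2O[Si](C)(C)C(C)(C)C)c(=O)n(C)c1=O`: 9700 nM
Compound 3 `COC(=O)C(=O)CNC1=CS(=O)(=O)O[C@@]12[C@@H](CO[Si](C)(C)C(C)(C)C)O[C@@H](n1cc(C)c(=O)n(C)c1=O)[C@@H]2O[Si](C)(C)C(C)(C)C`: > 200000 nM (a limit)

All three share one core and differ only in the group on the amine nitrogen. In a functional assay on HEL cells (Homo sapiens) (on this read-out higher numbers stand for lower toxicity in this test and lower numbers for higher toxicity in this test), compound 1 gives 14000 nM and compound 2 gives 9700 nM; the step of a 1.4-fold lower number from compound 1 to compound 2 (0.16 log units; within the scatter) is small. Going by these compounds, for compound 3 this assay reports only a limit, > 200000 nM, so its exact number is unknown; it sits at the limit of > 200000 nM in this assay, at which 1 of the 3 values shown sits. The steps of an at least 14-fold higher number from compound 1 to compound 3 (1.15 log units; beyond the scatter) and an at least 20-fold higher number from compound 2 to compound 3 (1.31 log units; beyond the scatter) are both large. Compound 4 `Cc1cn([C@@H]2O[C@H](CO[Si](C)(C)C(C)(C)C)[C@@]3(OS(=O)(=O)C=C3NCCC(N)=O)[C@H]2O[Si](C)(C)C(C)(C)C)c(=O)n(C)c1=O` differs from compound 3 in one place: carbamoylmethyl in place of (methoxycarbonyl)carbonyl on a saturated chain carbon bound to an amine nitrogen. A saturated chain stays on the amine nitrogen, unlike the (ethoxycarbonyl)carbamoyl of compound 1 or the benzoyl of compound 2, so the expected step is a number no higher from compound 3 to compound 4 (the limit leaves the size open), nothing beyond the scatter. Compound 4 is estimated at 200000 nM, ranging from 60000 nM to 600000 nM, and this assay may again report only a limit.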

Compound 4, half-maximal cytotoxic concentration: 14800 nM
For compound 4 the middle estimate is 14-fold (1.13 log units) above the measured one; the whole stated range lies above it.
By their numbers in this assay, from the lowest: compounds 2, 1 and 4 (each within the scatter of the next). At a limit, above all of these: compound 3.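

Keeping a saturated chain on the amine nitrogen is not enough to hold the number high in this assay: carbamoylmethyl in place of (methoxycarbonyl)carbonyl gives an at least 13-fold lower number from compound 3 to compound 4 (1.13 log units; beyond the scatter). The 2-carbamoylethyl group instead sits level with benzoyl and (ethoxycarbonyl)carbamoyl, as a 1.5-fold higher number from compound 2 to compound 4 (0.18 log units; within the scatter) and a 1.1-fold higher number from compound 1 to compound 4 (0.02 log units; within the scatter) are both within the scatter. Compound 3 stands at a limit: the limit of > 200000 nM in this assay, at which 1 of the 4 values shown sits.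

Going by these compounds, what stays open is which part of (methoxycarbonyl)carbonyl goes with the high number, and whether a carboxylic acid or an amine at the end of the chain would sit with compound 3 or with compound 4.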